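This account rests on a few compounds, and the source may have more. Where it says the series, first, only, none or still open, it means among the compounds named here.

Measured so far in an ADME assay on microsomes from liver (Homo sapiens) for metabolic stability, read by LC-MS, tested at 0.5 uM; a lower number here means that the compound disappears faster, a higher number that the compound lasts longer:

- compound 1 `Cc1nc(C)c([C@H](OC(C)(C)C)C(=O)O)c(N2CCC(C)(C)CC2)c1-c1ccc(OCCc2ccc(F)cc2F)cc1`: 1.08 h
- compound 2 `Cc1nc(C)c([C@H](OC(C)(C)C)C(=O)O)c(N2CCC(C)(C)CC2)c1-c1ccc(OCCc2cc(F)c(F)cc2F)cc1`: a limit, > 2 h
- compound 3 `Cc1nc(C)c([C@H](OC(C)(C)C)C(=O)O)c(N2CCC(C)(C)CC2)c1-c1ccc(OCCc2cccnc2)cc1`: 0.367 h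

Compound 1 holds the highest of the two plain numbers; compound 3 sits a 2.9-fold lower number from compound 1 to compound 3 (0.47 log units; beyond the scatter) below it. The value of compound 2 is a limit of this assay and not a number, and of the three values shown (the limit of > 2 h in this assay, at which 1 of the 3 values shown sits). The step from compound 1 to compound 2 reads an at least 1.8-fold higher number from compound 1 to compound 2 (0.26 log units; that floor lies within the scatter), a floor that stays within the scatter.

Compound 4 `Cc1ncsc1CCOc1ccc(-c2c(C)nc(C)c([C@H](OC(C)(C)C)C(=O)O)c2N2CCC(C)(C)CC2)cc1` is not yet measured. It differs from compound 1 as follows: 4-methyl-1,3-thiazol-5-yl in place of 2,4-difluorophenyl on a saturated chain carbon, two bonds along the chain from an oxygen on an aromatic ring. The measured steps that bear on this are the two at the same place that swap a fluorinated phenyl for a six-membered aromatic ring with a nitrogen: a 2.9-fold lower number from compound 1 to compound 3 (0.47 log units; beyond the scatter) and an at least 5.4-fold lower number from compound 2 to compound 3 (0.73 log units; beyond the scatter). Both run downward and both lie beyond the scatter, so a lower number in this assay is expected for compound 4, of modest size.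

Compound 4 is therefore expected to give 0.5 h, in the range 0.25 h to 1 h. That expected value means a step of a 2.2-fold lower number from compound 1 to compound 4 (0.33 log units; beyond the scatter).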

Compound 4, half-life: 1.5 h
For compound 4 the middle estimate is 3.0-fold (0.48 log units) below the measured one, outside the stated range (above it).
By their numbers in this assay, from the lowest: compound 3; then compounds 1 and 4 (each within the scatter of the next). At a limit, above all of these: compound 2.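

In this assay, 4-methyl-1,3-thiazol-5-yl in place of 2,4-difluorophenyl on this chain gives a 1.4-fold higher number from compound 1 to compound 4 (0.14 log units; within the scatter), so the downward step seen with pyridin-3-yl does not hold for every ring carrying nitrogen at this position, and compound 4 goes against that pattern. The two nitrogen-bearing rings themselves are separated clearly, with a 4.1-fold higher number from compound 3 to compound 4 (0.61 log units; beyond the scatter). Compound 2 has a limit and not a number, so its step reads only as a floor, an at least 1.3-fold lower number from compound 2 to compound 4 (0.12 log units; that floor lies within the scatter), and no order follows from it: the limit of > 2 h in this assay, at which 1 of the 4 values shown sits.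

Open, going by these compounds, is which part of 4-methyl-1,3-thiazol-5-yl matters, which a thiazol-5-yl without the methyl or a methyl-bearing pyridin-3-yl would help to separate. Also open, on these data alone, is whether these ring differences persist on a longer chain.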